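Trifluoromethyl in place of isopropoxy on the carbamate carbonyl

The source may report more compounds than this note shows. Statements on the series, on what has been measured and on what is new or still open speak of the compounds shown alone.

Of the compounds shown here, three that share a core have been measured in a functional assay on isolated protein for inhibition of Glucose-dependent insulinotropic receptor (Rattus norvegicus), read by HTRF and cAMP accumulation; on this read-out higher numbers stand for larger maximal responses and lower numbers for smaller maximal responses. Compound 1 `Cc1nc(S(C)(=O)=O)ccc1Oc1ncnc(OC2CCN(C(=O)OC(C)C)CC2)c1F` gives 77% in this assay, the second highest of the three numbers. Compound 2 `Cc1nc(S(C)(=O)=O)ccc1Oc1ncnc(OC2CCN(C(=O)OC(C)(C)C#N)CC2)c1F` gives 97%, and compound 3 `Cc1nc(S(C)(=O)=O)ccc1Oc1ncnc(OC2CCN(C(=S)OC3(C)CC3)CC2)c1F` gives 49%. The step of a number 20 percentage points higher from compound 1 to compound 2 (beyond the scatter) and the step of a number 28 percentage points lower from compound 1 to compound 3 (beyond the scatter) both lie beyond the scatter, and the step of a number 48 percentage points lower from compound 2 to compound 3 (beyond the scatter) is the largest of the set.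

Compound 4 `Cc1nc(S(C)(=O)=O)ccc1Oc1ncnc(OC2CCN(C(=O)C(F)(F)F)CC2)c1F` has not yet been measured. It differs from compound 1 by trifluoromethyl in place of isopropoxy on a carbonyl carbon, on a carbonyl carbon whose other neighbour is the amide-type nitrogen in a ring. Within the data shown here, no measured step changes this position in the same way: the steps from compound 1 to compound 2 and from compound 1 to compound 3 alter the group bound to the ring nitrogen in other ways, and both moved the maximal response beyond the scatter, in opposite directions. The data therefore show that this part of the molecule matters, but give no direction for the change at hand. Compound 4 is expected to give 62% in this assay, estimated between 35% and 90%, which amounts to an expected step of a number 15 percentage points lower from compound 1 to compound 4 (beyond the scatter).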

Compound 4, largest response reached (reported as efficacy), in percent of the reference or control that the assay uses: 76%
Estimate against measurement, compound 4: 14 percentage points below; the range from low to high includes it.
By their numbers in this assay, from the lowest: compound 3; then compounds 4 and 1 (each within the scatter of the next); then compound 2.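

In this assay, trifluoromethyl in place of isopropoxy on the carbonyl carbon gives a number 1 percentage points lower from compound 1 to compound 4 (within the scatter), so the isopropoxy group, with its oxygen and its hydrogen-bond acceptor, can leave this position without a change in maximal response beyond the scatter. Among these compounds, the group on the ring nitrogen still matters, since a number 21 percentage points lower from compound 2 to compound 4 (beyond the scatter) and a number 27 percentage points higher from compound 3 to compound 4 (beyond the scatter), and the earlier compounds could not show that a group with no oxygen on the carbonyl carbon would stay level with the isopropoxy carbamate of compound 1. No measurement shown here accounts for this result.

The compounds shown leave open whether the maximal response would also hold with a plain methyl, a longer chain such as pentafluoroethyl, or an amine such as dimethylamino on this carbonyl carbon. They also leave open whether trifluoromethyl and isopropoxy would remain level with each other on a core other than the one shared here, or whether the match seen between compound 1 and compound 4 belongs to this core alone.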